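The source may report more compounds than this note shows. Statements on the series, on what has been measured and on what is new or still open speak of the compounds shown alone.

In an ADME assay on PBMC cells (Homo sapiens) for cytotoxicity, with a stated time of 5 days (a higher number here means a weaker inhibitor, a lower number a stronger inhibitor), compound 3 `c1csc(C2=NNC(c3ccc(N4CCCCC4)cc3)C2)c1` gives 20800 nM, and compound 1 `Cc1ccsc1C(=O)/C=C/c1ccc(N2CCCCC2)cc1` gives 26400 nM, the two numbers lying within the usual scatter of each other. Compound 2 `O=C(/C=C/c1ccc(N2CCCCC2)cc1)c1ccc(Cl)s1` gives only a limit, > 100000 nM. Compound 4 `Clc1ccsc1C1=NNC(c2ccc(N3CCCCC3)cc2)C1` differs from compound 3 in one place: chloro in place of hydrogen on an aromatic carbon. For the measured compounds named here, only one measured step exists, an at least 3.7-fold higher number from compound 1 to compound 2 (0.57 log units; beyond the scatter), and it exchanges one thiophene substituent for another on a carbonyl-bearing core rather than on the core shared by compound 3 and compound 4. Going by these compounds, compound 2 sits at the limit of > 100000 nM in this assay, at which 1 of the 3 values shown sits, so the true size of that step is unknown. It points, weakly, toward a higher number when a chloro sits on the thiophene. The step of a 1.4-fold higher number from compound 3 to compound 4 (0.16 log units; within the scatter) is therefore expected to be small and upward, close to the scatter. Compound 4 is estimated at 30000 nM, with a likely range from 10000 nM to 100000 nM, and a real chance that only a limit is reported.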

Compound 4, half-maximal inhibitory concentration: 34200 nM
Estimate against measurement, compound 4: 1.1-fold (0.06 log units) below; the measured number falls inside the stated range.
By their numbers in this assay, from the lowest: compounds 3, 1 and 4 (each within the scatter of the next). At a limit, above all of these: compound 2.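

In this assay, the new reading is a 1.6-fold higher number from compound 3 to compound 4 (0.22 log units; within the scatter). This is the first step shown on the core shared by compound 3 and compound 4, and it shows that a chloro can sit on this aromatic carbon, next to the ring atom that bears a large group, with no difference that can be told from scatter. The earlier step to 5-chlorothiophen-2-yl lay on a different core, and with so small a step, nothing shown here speaks to any cause.

Going by these compounds, whether a methyl, a methoxy or an amine at this same place would read alike remains open. So does the reading of a 5-chlorothiophen-2-yl group on the core of compound 3.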